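Swapping the amide aryl group: from compound 3 to compound 4

The compounds below may be only part of what the source reports. "The series", "measured", "known", "first", "only" and "open" are said of these compounds alone.

Measured compounds in a functional assay on GTL 16 cells for antiproliferative activity against GTL 16 cell line (Homo sapiens), read by CCK-8 assay, with a stated time of 72 h; a higher number here means a weaker inhibitor, a lower number a stronger inhibitor:
- compound 1, `Cc1ccc(C(=O)Nc2cccc(-c3oc4cc(-c5ccc(F)cc5)ccc4c(=O)c3O)c2)cc1`: 12900 nM
- compound 2, `O=C(Nc1cccc(-c2oc3cc(-c4ccc(F)cc4)ccc3c(=O)c2O)c1)c1ccc(C(F)(F)F)cc1`: 33000 nM
- compound 3, `Cc1cc(C(=O)Nc2cccc(-c3oc4cc(-c5ccc(F)cc5)ccc4c(=O)c3O)c2)ccc1F`: 12100 nM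

All three share the same core and differ only in the aryl group attached to the amide carbonyl. Compound 3 gives the lowest number of the three in this assay, but its gap to compound 1 is within the scatter, so the two cannot be ordered; only compound 2 stands apart, as the step of a 2.7-fold lower number from compound 2 to compound 3 (0.44 log units; beyond the scatter) shows.

Compound 4, `O=C(Nc1cccc(-c2oc3cc(-c4ccc(F)cc4)ccc3c(=O)c2O)c1)c1cc(F)cc(F)c1`, is not yet measured. It differs from compound 3 by 3,5-difluorophenyl in place of 4-fluoro-3-methylphenyl on a carbonyl carbon.

Going by the values given here, two measured steps bear on this. The step of a 1.1-fold lower number from compound 1 to compound 3 (0.03 log units; within the scatter) shows that adding a fluorine while keeping a methyl changed nothing beyond the scatter. The step of a 2.6-fold higher number from compound 1 to compound 2 (0.41 log units; beyond the scatter) shows that replacing the methyl altogether with a fluorinated group gave a modest rise in the number. Compound 4 loses the methyl and gains a second fluorine, so a small rise, possibly within the scatter, is expected: a 1.3-fold higher number from compound 3 to compound 4 (0.12 log units; within the scatter).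

Compound 4 is therefore estimated at 16000 nM in this assay, with a range from 7000 nM to 38000 nM.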

Compound 4, half-maximal inhibitory concentration: 7410 nM
The estimate for compound 4 lay 2.2-fold (0.33 log units) above the measured number; the range from low to high includes it.
By their numbers in this assay, from the lowest: compounds 4, 3 and 1 (each within the scatter of the next); then compound 2.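

In this assay, the methyl group is not needed at this place on the amide carbonyl: a 1.6-fold lower number from compound 3 to compound 4 (0.21 log units; within the scatter) and a 1.7-fold lower number from compound 1 to compound 4 (0.24 log units; within the scatter) both lie within the scatter, so compound 4 cannot be ordered against either compound that has a methyl. Fluorine on this ring therefore does not by itself go with a higher number, as 3,5-difluorophenyl stands clearly apart from 4-(trifluoromethyl)phenyl in the modest step of a 4.5-fold lower number from compound 2 to compound 4 (0.65 log units; beyond the scatter). No measurement available here explains this difference between the groups.

The compounds shown leave open whether this ring can carry something other than methyl or fluorine-containing groups, such as an amine or a carboxylic acid. They also leave open how an unsubstituted phenyl or a monofluorophenyl would compare.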